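Working notes: the step from compound 2 to compound 3

The source may report more compounds than this note shows. Statements on the series, on what has been measured and on what is new or still open speak of the compounds shown alone.

Values so far in a functional assay on SMMC-7721 cells (Homo sapiens) for antiproliferative activity, read by MTT assay, with a stated time of 48 h (a lower number here means a stronger inhibitor, a higher number a weaker inhibitor), are as follows:
- compound 1 `Cn1cc(C2=C(c3nn(CCCn4ccnc4)c4ncccc34)C(=O)N(c3ccccc3)C2=O)c2ccccc21` gives 34800 nM
- compound 2 `CN1CCN(CCCn2nc(C3=C(c4cn(C)c5ccccc45)C(=O)NC3=O)c3cccnc32)CC1` gives > 100000 nM as a limit

Compound 2 stands at the limit of this assay with > 100000 nM as its entry, which is a limit and not a number. Compound 3 `Cn1cc(C2=C(c3nn(CCn4ccnc4)c4ncccc34)C(=O)NC2=O)c2ccccc21` follows from compound 2 by the change 1H-imidazol-1-yl in place of (4-methylpiperazin-1-yl)methyl on a saturated chain carbon, two bonds along the chain from an aromatic nitrogen with 1H-imidazol-1-yl in place of (4-methylpiperazin-1-yl)methyl on a saturated chain carbon, two bonds along the chain from an aromatic nitrogen. Cut one bond further out, this reads 3-(4-methylpiperazin-1-yl)propyl to 2-(1H-imidazol-1-yl)ethyl. Going by the values given here, no step between measured compounds is available to size this change. Compound 1 also carries 1H-imidazol-1-yl and gives 34800 nM as a true number, so a moderate move toward stronger inhibition is expected. A second limit remains possible for compound 3. The expected step is an at least 2.5-fold lower number from compound 2 to compound 3 (0.39 log units; beyond the scatter) in the direction of stronger inhibition. For compound 3 the estimate is 40000 nM with an expected range of 12000 nM to 100000 nM in this assay series.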

Compound 3, half-maximal inhibitory concentration: > 100000 nM
Compound 3: only a limit was reported (the forecaster's own chance of this, stated with the estimate: 25%); middle value at least 2.5-fold (0.39 log units) from the limit.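

In this assay compound 3 gives > 100000 nM, a limit and not a number, as does compound 2, so no step can be read between compound 2 and compound 3. The compounds shown leave open what 1H-imidazol-1-yl in place of (4-methylpiperazin-1-yl)methyl does to the inhibition, in size or in direction.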